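The compounds below may be only part of what the source reports. "The series", "measured", "known", "first", "only" and "open" are said of these compounds alone.

Measured so far in a functional assay on DLD-1 cells (Homo sapiens) for inhibition, read by MTT assay, with a stated time of 72 h; a lower number here means a stronger inhibitor, a higher number a weaker inhibitor:
compound 1 `COc1cc(Oc2cccc(Nc3ccccc3)c2)cc(OC)c1CNCc1ccc(Br)cc1` — compound 1 gives 3520 nM
compound 2 `COc1cc(Oc2cccc(Nc3ccccc3)c2)cc(OC)c1CNCc1ccc(Cl)cc1` — compound 2 gives 3740 nM

Compound 2 carries the highest number of the two, but the step of a 1.1-fold higher number from compound 1 to compound 2 (0.03 log units; within the scatter) lies within the scatter, so compound 1 and compound 2 cannot be told apart on these numbers.

Compound 3 `COc1cc(Oc2cccc(Nc3ccccc3)c2)cc(OC)c1CNCc1ccc(F)cc1` is the next member of the series. It differs from compound 2 in one place: fluoro in place of chloro on an aromatic carbon. Among the measured compounds shown here, the one measured step that bears on this kind of exchange is a 1.1-fold higher number from compound 1 to compound 2 (0.03 log units; within the scatter), in which swapping one such substituent for another at the same place moved the number by an amount within the scatter. For the measured compounds named here, no other step speaks to this change.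

The expected step is therefore a 1.0-fold higher number from compound 2 to compound 3 (0.01 log units; within the scatter), which is to say no shift beyond the scatter in this assay. The estimate for compound 3 is 3800 nM, with the range 1900 nM to 7600 nM.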

Compound 3, half-maximal inhibitory concentration: 2650 nM
Estimate against measurement, compound 3: 1.4-fold (0.16 log units) above; measured number inside the range.
By their numbers in this assay, from the lowest: compounds 3, 1 and 2 (each within the scatter of the next).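

The step of a 1.4-fold lower number from compound 2 to compound 3 (0.15 log units; within the scatter) and the step of a 1.3-fold lower number from compound 1 to compound 3 (0.12 log units; within the scatter) both stay within the scatter in this assay, so fluoro, chloro and bromo cannot be told apart at this place, para to a large group. The earlier pair covered only bromo and chloro; with fluoro added, the three compounds still give no order among these halogens. Nothing measured here offers an explanation for these numbers.

Open, as far as these compounds go, is whether a group other than a halogen at this place, such as a methoxy group, a nitrile, an amine or a carboxylic acid, would move the number beyond the scatter. Also open, from the compounds shown here alone, is how the unsubstituted benzyl compound, with hydrogen at this place, would compare with these three.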